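From compound 2 to compound 4: adding piperidin-1-yl

The source may report more compounds than this note shows. Statements on the series, on what has been measured and on what is new or still open speak of the compounds shown alone.

- compound 1 `Cc1ccccc1Nc1nc(NC2CCCCC2)ncc1Cl`: > 100000 nM (a limit)
- compound 2 `Cc1ccccc1Nc1nc(Nc2ccccc2)ncc1Cl`: > 100000 nM (a limit)
- compound 3 `Cc1ccccc1Nc1nc(NCc2ccco2)ncc1Cl`: > 100000 nM (a limit)

In a functional assay on MCF7 cells (Homo sapiens) for inhibition, read by CCK-8 assay, with a stated time of 48 h (a higher number here means a weaker inhibitor of growth, a lower number a stronger inhibitor of growth), compound 2 gives > 100000 nM, which is a limit and not a number. All three compounds rest on (the limit of > 100000 nM in this assay, at which 3 of the 3 values shown sit).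

Compound 4 `Cc1ccccc1Nc1nc(Nc2ccc(N3CCCCC3)cc2)ncc1Cl` carries piperidin-1-yl in place of hydrogen on an aromatic carbon of compound 2: piperidin-1-yl in place of hydrogen on an aromatic carbon.

The measured steps all concern the group on the nitrogen: a step that the two limits leave unreadable from compound 1 to compound 2, a step that the two limits leave unreadable from compound 1 to compound 3 and a step that the two limits leave unreadable from compound 2 to compound 3. They therefore offer no size to carry over, and none of them adds a group at this place.

In this assay the expected size is an at least 3.3-fold lower number from compound 2 to compound 4 (0.52 log units; beyond the scatter), an estimate toward stronger growth inhibition, though another limit remains quite possible. Compound 4 is estimated at 30000 nM, with an expected range from 4000 nM to 100000 nM.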

Compound 4, concentration for 50% growth inhibition: > 100000 nM
Compound 4: no number, only a limit; the forecaster's own chance of this, stated with the estimate: 40%; middle value at least 3.3-fold (0.52 log units) away from the limit.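

Compound 4 gives > 100000 nM, which is a limit and not a number. Compound 2 also rests on a limit, so no size can be read for adding piperidin-1-yl. The compounds shown leave open what change, if any, would give a measurable value.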